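A few compounds are considered here, and "the series" means these few. Any claim that something is new, unique, unknown or untested is made for them only; others in the source may bear on it.

Measured compounds:
- compound 1, `CCS(=O)(=O)Nc1ccc2c(c1)/C(=C(/Nc1ccc(C)cc1)c1ccccc1)C(=O)N2`: 3.1 uM
- compound 2, `CS(=O)(=O)Nc1ccc2c(c1)/C(=C(/Nc1ccc(CN3CCCCC3)cc1)c1ccccc1)C(=O)N2`: 0.2 uM
- compound 3, `CC(=O)N1C(=O)/C(=C(\Nc2ccc(CN3CCCCC3)cc2)c2ccccc2)c2cc(N)ccc21`: 1.81 uM

Of the compounds shown here, three sharing one core have been tested in an ADME assay on HepG2 cells (Homo sapiens) for cytotoxicity, read by MTT assay, with a stated time of 48 h; a higher number here means that more compound is tolerated, a lower number that less compound is tolerated. Compound 1 gives 3.1 uM, compound 3 gives 1.81 uM, and compound 2 gives 0.2 uM. Among these three, compound 2 stands at the lowest number: its gap to compound 3, the nearest, and its gap to compound 1, the furthest, both lie beyond the usual scatter, so compound 2 is the least well tolerated of the three in this assay.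

Compound 4, `O=C1Nc2ccccc2/C1=C(/Nc1ccc(CN2CCCCC2)cc1)c1ccccc1`, has not yet been measured. It differs from compound 2 in one place: hydrogen in place of methanesulfonamido on an aromatic carbon. Among the compounds with values here, no pair of measured compounds differs in just this way, so there is no directly comparable step to lean on. A modest step, most likely towards a somewhat higher number in this assay, is expected, and it may well stay within the scatter: a 2.5-fold higher number from compound 2 to compound 4 (0.40 log units; beyond the scatter). Compound 4 is expected to give about 0.5 uM, with a range from 0.15 uM to 2 uM.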

Compound 4, half-maximal toxic concentration: > 6 uM
Compound 4 gave a limit, no number (the forecaster's own chance of this, stated with the estimate: 5%); middle value at least 12-fold (1.07 log units) from the limit.
By their numbers in this assay, from the lowest: compound 2; then compounds 3 and 1 (each within the scatter of the next). At a limit, above all of these: compound 4.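

In this assay, hydrogen in place of methanesulfonamido on this aromatic carbon brings an at least 30-fold higher number from compound 2 to compound 4 (1.47 log units; beyond the scatter). Within the data shown here, no two of the earlier compounds differ in one place only, so this is the first sign that this single position, on its own, can change cell tolerance by a large margin. Compound 4 gives > 6 uM, which is a limit of the assay and not a number, so the step marks only the smallest change the data allow: the limit of > 6 uM in this assay, at which 1 of the 4 values shown sits.

Going by these compounds, it remains open how far the tolerance of compound 4 extends past this limit. On these data alone, it is also open whether another group on this carbon, such as a methoxy group, a fluorine atom or a carboxylic acid, would give a number closer to compound 2 or to compound 4.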